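Pyridyl urea series: two substituents exchanged at once

The source may report more compounds than this note shows. Statements on the series, on what has been measured and on what is new or still open speak of the compounds shown alone.

Compound 3 `Cc1cc(S(C)(=O)=O)c(NC(=O)N(Cc2ccc(Oc3ccc(F)cc3)cc2)C2CCCCCC2)c(Cl)n1` gives the lowest number of the three measured in an assay for inhibition of acyl-CoA:cholesterol acyltransferase (Oryctolagus cuniculus), using microsomes (on this read-out higher numbers stand for weaker inhibition and lower numbers for stronger inhibition), at 30 nM. Compound 1 `CSc1cc(C)nc(Cl)c1NC(=O)N(Cc1ccc(Oc2ccc(F)cc2)cc1)C1CCCCCC1` gives 46 nM and compound 2 `CSc1cc(C)nc(S(C)(=O)=O)c1NC(=O)N(Cc1ccc(Oc2ccc(F)cc2)cc1)C1CCCCCC1` gives 78 nM; the gap from compound 3 to compound 1 lies within the scatter, the gap to compound 2 beyond it. Compound 4 `CSc1cc(C)nc(C)c1NC(=O)N(Cc1ccc(Oc2ccc(F)cc2)cc1)C1CCCCCC1` carries a group of 10 heavy atoms (8 carbon, 1 nitrogen, 1 sulfur; one six-membered aromatic ring with 1 hetero atom) in place of a group of 12 heavy atoms (7 carbon, 1 nitrogen, 2 oxygen, 1 sulfur, 1 chlorine; one six-membered aromatic ring with 1 hetero atom), on an amide-type nitrogen. For the measured compounds named here, two measured steps bear on this change: a 1.5-fold lower number from compound 1 to compound 3 (0.19 log units; within the scatter) and a 1.7-fold higher number from compound 1 to compound 2 (0.23 log units; within the scatter), both within the scatter, so such exchanges have so far moved the number little. Compound 4 is therefore expected to stay close to compound 1 and compound 3, with a 1.7-fold higher number from compound 3 to compound 4 (0.22 log units; within the scatter). The estimate for compound 4 is 50 nM, within 20 nM to 130 nM.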

Compound 4, half-maximal inhibitory concentration: 90 nM
The estimate for compound 4 lay 1.8-fold (0.26 log units) below the measured number, within the range that was stated.
By their numbers in this assay, from the lowest: compounds 3, 1, 2 and 4 (each within the scatter of the next, the first and the last beyond it).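

Methyl in place of chloro gives a 2.0-fold higher number from compound 1 to compound 4 (0.29 log units; within the scatter) and methyl in place of methylsulfonyl gives a 1.2-fold higher number from compound 2 to compound 4 (0.06 log units; within the scatter) so on this aromatic carbon methyl is not separated from either group. Only the exchange on the amide-type nitrogen, which alters two substituents at once, gives a step beyond the scatter: a 3.0-fold higher number from compound 3 to compound 4 (0.48 log units; beyond the scatter) and that larger step appears only with both substituents changed. No measurement at hand accounts for these steps.

From the compounds shown here alone, whether an amino or methoxy group on this aromatic carbon would separate from methyl remains open.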